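This account rests on a few compounds, and the source may have more. Where it says the series, first, only, none or still open, it means among the compounds named here.

Compound 3 `CCCCCCCCc1ccc(OCC(=O)Cn2cnnn2)cc1` is one of three compounds that share a core and differ only in the ring attached to the saturated chain carbon bound to the carbonyl carbon. In an assay on microsomes from brain for inhibition of Fatty-acid amide hydrolase 1 (Rattus norvegicus), read by fluorescence and HPLC, with a stated time of 60 min (a higher number here means a weaker inhibitor, a lower number a stronger inhibitor), compound 3 gives 39 nM, the second highest of the three numbers. Its nearest neighbour is compound 2 `CCCCCCCCc1ccc(OCC(=O)Cn2nnc3cccnc32)cc1`, which in this assay gives 13 nM; the step of a 3.0-fold higher number from compound 2 to compound 3 (0.48 log units; beyond the scatter) lies beyond the scatter. The furthest is compound 1 `CCCCCCCCc1ccc(OCC(=O)Cn2cnc3ccccc32)cc1`, which in this assay gives 480 nM; here a 12-fold lower number from compound 1 to compound 3 (1.09 log units; beyond the scatter). The largest measured step is a 37-fold lower number from compound 1 to compound 2 (1.57 log units; beyond the scatter).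

Compound 4 `O=C(COc1ccc(-c2ccccc2)cc1)Cn1cnnn1` keeps the tetrazolyl ring of compound 3 and alters the other end of the molecule: phenyl in place of octyl on an aromatic carbon. For the measured compounds named here, none of the measured steps bears on this change: compound 1, compound 2 and compound 3 all carry the same octyl group, and every measured step concerns the ring on the saturated chain carbon, not the aromatic carbon. There is thus no measured guide to the size or direction of this step, and the expectation has to remain wide. Compound 4 is estimated at 150 nM, with a range from 30 nM to 800 nM. Going by the values given here, this estimate means an expected step of a 3.8-fold higher number from compound 3 to compound 4 (0.59 log units; beyond the scatter), a move toward a weaker inhibitor that rests on no measured step and is therefore given a broad range.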

Compound 4, half-maximal inhibitory concentration: 43 nM
For compound 4 the middle estimate is 3.5-fold (0.54 log units) above the measured one; the measured number falls inside the stated range.
By their numbers in this assay, from the lowest: compound 2; then compounds 3 and 4 (each within the scatter of the next); then compound 1.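

In this assay, the step of a 1.1-fold higher number from compound 3 to compound 4 (0.04 log units; within the scatter) shows that, with the tetrazolyl ring held fixed, phenyl can stand in place of octyl on this aromatic carbon without a change that can be told from the scatter. For the compounds shown here, this is the first measured view of this end of the molecule, as compound 1, compound 2 and compound 3 all carry octyl and differ only in the ring on the saturated chain carbon. For the tetrazolyl series, then, the open octyl chain is not required for a number at the level of compound 3, and nothing in the material shown explains why these two different groups give such similar numbers.

On these data alone, it remains open whether phenyl would be tolerated in the same way alongside the ring of compound 2 or of compound 1, as this single step covers the tetrazolyl ring alone. Also open, as far as these compounds go, is what the same position would give with a shorter chain such as butyl, or with a phenyl ring carrying a carboxylic acid or an amine.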